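Methyl on the benzyloxy phenyl of a triazolethione pyrazole series

The compounds below may be only part of what the source reports. "The series", "measured", "known", "first", "only" and "open" are said of these compounds alone.

Measured so far:
compound 1, `Fc1ccc(-c2n[nH]cc2/C=N/n2c(OCc3ccccc3)n[nH]c2=S)cc1`: 71 ug/mL in a functional assay on HepG2 cells (Homo sapiens) for cytotoxicity, read by MTT assay, with a stated time of 24 h; a lower number here means a stronger inhibitor, a higher number a weaker inhibitor
compound 2, `Cc1ccc(COc2nn(CN(c3ccccc3)c3ccccc3)c(=S)n2/N=C/c2c[nH]nc2-c2ccc(Cl)cc2)cc1`: 97 ug/mL

Compound 1 has the lower of the two numbers in this assay, but compound 2 lies within the scatter of it, so the two values show no difference that can be read as order. Within the data shown here, compound 2 also differs from compound 1 in more than one place, and no single step between the measured compounds is available.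

Compound 3, `Cc1ccc(COc2n[nH]c(=S)n2/N=C/c2c[nH]nc2-c2ccc(F)cc2)cc1`, is compound 1 with one change: methyl in place of hydrogen on an aromatic carbon, on an aromatic carbon of a six-membered aromatic ring of carbon only, para to a large group; read one bond further out, benzyloxy becomes (4-methylbenzyl)oxy.

Among the measured compounds shown here, no measured step supports a direction for this change. A methyl in place of hydrogen on an aromatic carbon is a small change, and with nothing shown in the series to point either way, the expected step is none beyond the scatter. Compound 3 is therefore estimated at 75 ug/mL, range 35 ug/mL to 160 ug/mL, an expected step of a 1.1-fold higher number from compound 1 to compound 3 (0.02 log units; within the scatter) from compound 1.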

Compound 3, half-maximal inhibitory concentration: 45 ug/mL
The estimate for compound 3 lay 1.7-fold (0.22 log units) above the measured number; measured number inside the range.
By their numbers in this assay, from the lowest: compounds 3, 1 and 2 (each within the scatter of the next, the first and the last beyond it).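

Among these compounds, this is the first step that differs in one place only: in this assay, methyl in place of hydrogen on an aromatic carbon, para to a large group, turning benzyloxy into (4-methylbenzyl)oxy, gives a 1.6-fold lower number from compound 1 to compound 3 (0.20 log units; within the scatter). This position on the six-membered aromatic ring of carbon only therefore accepts a methyl with no difference that can be read as a gain or a loss, and the step gives no direction for this change. Nothing on hand bears on why the step has this size.

As far as these compounds go, whether another group on this same carbon, such as a methoxy, an amine, a carboxylic acid or a longer chain, would give a step beyond the scatter remains open, and a single methyl cannot settle what this position allows. The steps that would link compound 2 to compound 1 or compound 3 cannot be read, since compound 2 differs from each in more than one place, so the methyl step cannot yet be checked in a second pair of compounds.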